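Series notes: (pyridin-2-yl)oxy in place of pyridin-3-yl

The compounds below may be only part of what the source reports. "The series", "measured", "known", "first", "only" and "open" are said of these compounds alone.

Measured so far:
Compound 1 `CNC(=O)/C=C/c1ccc2noc(-c3ccccc3)c2c1`: in an assay for inhibition of inositol hexakisphosphate kinase 2 (Homo sapiens), read by colorimetric assay, coupled enzyme assay and malachite green, with a stated time of 120 min, in the presence of a further agent that is not named here (on this read-out lower numbers stand for stronger inhibition and higher numbers for weaker inhibition), compound 1 gives 58200 nM.
Compound 2 `CNC(=O)c1ccc2noc(-c3ccccc3)c2c1`: in this assay compound 2 gives 2120 nM.
Compound 3 `O=C(O)c1ccc2noc(-c3ccc(-c4cccnc4)cc3)c2c1`: in this assay compound 3 gives 54 nM.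

Compound 3 stands at the lowest number of the three in this assay; its gap to compound 2, and the larger gap to compound 1, both lie beyond the scatter. Going by the values given here, the single measured step, a 27-fold lower number from compound 1 to compound 2 (1.44 log units; beyond the scatter), concerns the group attached on the other side of the shared core and says nothing about the aryl substituent that carries the pyridine.

Compound 4 `O=C(O)c1ccc2noc(-c3ccc(Oc4ccccn4)cc3)c2c1` differs from compound 3 by (pyridin-2-yl)oxy in place of pyridin-3-yl on an aromatic carbon. Among the compounds with values here, no measured pair bears on this change: nothing shows what exchanging the directly attached pyridine for an oxygen-linked one does in this assay. The working expectation is therefore a step of no clear direction, with a range widened on both sides to cover the lack of a precedent. Compound 4 is estimated at 80 nM, within 20 nM to 320 nM. The step this estimate implies, a 1.5-fold higher number from compound 3 to compound 4 (0.17 log units; within the scatter), is expected to remain inside the scatter.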

Compound 4, half-maximal inhibitory concentration: 1190 nM
For compound 4 the middle estimate is 15-fold (1.17 log units) below the measured one; measured number outside the range, above it.
By their numbers in this assay, from the lowest: compound 3; then compounds 4 and 2 (each within the scatter of the next); then compound 1.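

Notes on the aryl substituent: in this assay this position is sensitive to the group it carries, as the step of a 22-fold higher number from compound 3 to compound 4 (1.34 log units; beyond the scatter) is the first measured at this site and lies beyond the scatter. The change is a combined one, since the entering (pyridin-2-yl)oxy group adds an oxygen link and also moves the ring nitrogen relative to the point of attachment, while the carboxylic acid and the shared core stay the same, so the pair fixes the size of the combined change and not the share of either part. Nothing measured here explains the step.

The compounds shown leave open whether the loss follows the oxygen link or the nitrogen placement, and a directly attached pyridin-2-yl group together with a (pyridin-3-yl)oxy group would separate the two. Also open, from the compounds shown here alone, is how a plain phenyl or a phenoxy group at this carbon would compare, and whether the same change behaves alike with a methylcarbamoyl group in place of the carboxylic acid on the other side of the core.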